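Trifluoromethyl for nitro on the amide aryl ring

The source may hold more compounds than are shown below. What is called first, only, known or untested is meant among the compounds shown, and "the series" means these compounds.

Going by the values given here, compound 2 `CCCCCCCCCCCCn1nnc(C(NC(=O)c2ccc([N+](=O)[O-])cc2)c2ccccc2)n1` gives 540 nM in an assay on microsomes from liver for inhibition of sterol O-acyltransferase 1 (Rattus norvegicus) (a lower number here means a stronger inhibitor, a higher number a weaker inhibitor), the larger of the two numbers measured so far. Compound 1 `CCCCCCCCCCCCn1nnc(C(NC(=O)c2c(C)cccc2C)c2ccccc2)n1` gives 310 nM, and the step of a 1.7-fold higher number from compound 1 to compound 2 (0.24 log units; within the scatter) lies within the scatter. Compound 3 `CCCCCCCCCCCCn1nnc(C(NC(=O)c2ccc(C(F)(F)F)cc2)c2ccccc2)n1` differs from compound 2 by trifluoromethyl in place of nitro on an aromatic carbon. Among the compounds with values here, the one step that bears on this change, a 1.7-fold higher number from compound 1 to compound 2 (0.24 log units; within the scatter), also altered the group on the carbonyl carbon and stayed within the scatter, so no shift beyond the scatter is expected for compound 3. Compound 3 is estimated at 450 nM, within 150 nM to 1400 nM. The expected step is a 1.2-fold lower number from compound 2 to compound 3 (0.08 log units; within the scatter).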

Compound 3, half-maximal inhibitory concentration: 850 nM
Estimate against measurement, compound 3: 1.9-fold (0.28 log units) below; the range from low to high includes it.
By their numbers in this assay, from the lowest: compounds 1, 2 and 3 (each within the scatter of the next, the first and the last beyond it).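

Nitro and trifluoromethyl on the aromatic carbon para to a large group are not told apart in this assay by this change, which gives a 1.6-fold higher number from compound 2 to compound 3 (0.20 log units; within the scatter) and so sets no order between them. Set against the 2,6-dimethylphenyl group, however, the 4-(trifluoromethyl)phenyl group gives a 2.7-fold higher number from compound 1 to compound 3 (0.44 log units; beyond the scatter) and this is the first step here to pass the scatter, if only modestly. Nothing at hand gives a reason for this step. The compounds shown leave open whether an amine or a carboxylic acid on this aromatic carbon would stand apart from nitro and trifluoromethyl, and how a shorter chain would read.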